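This account rests on a few compounds, and the source may have more. Where it says the series, first, only, none or still open, it means among the compounds named here.

Measured in an in vitro ADME assay on microsomes from liver (Macaca fascicularis) for metabolic stability; on this read-out higher numbers stand for fast clearance and lower numbers for slow clearance:
- compound 1 `Cc1ccc([C@H](C(=O)N(C)C)N2C(=O)[C@@H](C3Cc4ccccc4C3)NC(=O)[C@H]2CC(C)C)cn1`: 21000 mL.min-1.g-1
- compound 2 `CC[C@H](C)[C@@H]1C(=O)N[C@H](C2Cc3ccccc3C2)C(=O)N1[C@@H](C(=O)N(C)C)c1ccc(C)nc1C`: 14 mL.min-1.g-1

Compound 1 holds the higher of the two numbers, and compound 2 lies far lower, beyond the scatter. Compound 3 `Cc1ccc([C@H](C(=O)N(C)C)N2C(=O)[C@@H](C3Cc4ccccc4C3)NC(=O)[C@H]2CC(C)(C)C)cn1` keeps the core of compound 1 with one change: methyl in place of hydrogen on a saturated chain carbon bound to three saturated chain carbons. This is methyl in place of hydrogen on a saturated chain carbon bound to three saturated chain carbons, or isobutyl to neopentyl. Within the data shown here, no measured pair differs in one place only, so no measured step sets the size of this change. With compound 1 at 21000 mL.min-1.g-1 and compound 2 at 14 mL.min-1.g-1, the two values leave a very wide span, and a fall in this assay is expected, of uncertain size. The expected step is a 42-fold lower number from compound 1 to compound 3 (1.62 log units; beyond the scatter). For compound 3 the estimated value is 500 mL.min-1.g-1, with an expected range of 12 mL.min-1.g-1 to 25000 mL.min-1.g-1.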

Compound 3, intrinsic clearance in microsomes: 8 mL.min-1.g-1
The estimate for compound 3 lay 63-fold (1.80 log units) above the measured number; measured number outside the range, below it.
By their numbers in this assay, from the lowest: compounds 3 and 2 (each within the scatter of the next); then compound 1.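

In this assay, among these compounds, the change from isobutyl to neopentyl on the shared core gives a 2600-fold lower number from compound 1 to compound 3 (3.42 log units; beyond the scatter) and is the only step that sizes a change in one place. The methyl in place of hydrogen on a saturated chain carbon bound to three saturated chain carbons adds a single carbon, so at this position a very small change in the chain goes with a large fall in the read-out, and the high number of compound 1 does not hold for the core as a whole. Nothing at hand accounts for the size of this step.

As far as these compounds go, with one pair, it remains open whether a step of this size would recur on a different core. From the compounds shown here alone, how a longer chain, an amine or a carboxylic acid at this position would read also remains open.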